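The source may hold more compounds than are shown below. What is called first, only, known or untested is meant among the compounds shown, and "the series" means these compounds.

Measured in a functional assay on MDA-MB-435 cells (Homo sapiens) for inhibition, read by sulforhodamine B assay, with a stated time of 48 h, tested at 10 uM; on this read-out higher numbers stand for a weaker effect at the one concentration tested and lower numbers for a stronger effect:

Compound 1 `COc1cc2cc(Oc3ccc(NC(=O)Nc4ccccc4)cc3)c(C)nc2cc1OC`: 89.4%
Compound 2 `COc1cc2cc(Oc3ccc(NC(=O)Nc4cccc(C(F)(F)F)c4)cc3)c(C)nc2cc1OC`: 7.23%

Going by the values given here, of the two numbers so far, compound 2 stands lowest, meaning the stronger effect at the single concentration tested; its nearest neighbour is compound 1, and the step of a number 82.2 percentage points lower from compound 1 to compound 2 (beyond the scatter) is large and well beyond the usual scatter. That step came from trifluoromethyl in place of hydrogen on an aromatic carbon.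

Compound 3 `COc1cc2cc(Oc3ccc(NC(=O)Nc4ccc(Cl)c(C(F)(F)F)c4)cc3)c(C)nc2cc1OC` has not yet been measured. It differs from compound 2 in one place: chloro in place of hydrogen on an aromatic carbon, the chloro sitting ortho to the trifluoromethyl group already present. Among the compounds with values here, no measured step here involves a chloro group, so the only comparison available, the step from compound 1 to compound 2, speaks to a different change and does not bear directly on this one. Since compound 2 already gives 7.23%, there is little room for a further drop. The expectation is therefore a step of about a number 1.2 percentage points lower from compound 2 to compound 3 (within the scatter) in this assay, not beyond the scatter. Compound 3 is estimated at 6%, within a range from 0% to 25%.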

Compound 3, a percentage reported as activity, at one concentration (the size of the read-out at that concentration, not a potency): -25.7%
Estimate against measurement, compound 3: 31.7 percentage points above; the measured number lies below the stated range.
By their numbers in this assay, from the lowest: compound 3; then compound 2; then compound 1.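

In this assay, compound 2 at 7.23% turns out not to give the lowest number: adding a chloro ortho to the trifluoromethyl group gives a number 32.9 percentage points lower from compound 2 to compound 3 (beyond the scatter), and compound 3 reaches -25.7%, a number under zero. This position on the ring therefore still changes the read-out strongly even when the trifluoromethyl group is already in place, and replacing phenyl with 4-chloro-3-(trifluoromethyl)phenyl gives in all a number 115.1 percentage points lower from compound 1 to compound 3 (beyond the scatter). Nothing measured here explains why this single added chlorine atom has so large an effect.

The chloro is seen only alongside the trifluoromethyl group, so these compounds cannot show what it would do on the plain phenyl ring of compound 1, or whether the two groups need each other. They also leave open whether another group at the same position, such as fluoro, methyl, an amine or a carboxylic acid, would keep the number under zero or lose the effect.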